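The source may report more compounds than this note shows. Statements on the series, on what has been measured and on what is new or still open speak of the compounds shown alone.

Measured so far in a functional assay on HepG2 cells (Homo sapiens) for cytotoxicity, with a stated time of 24 h; on this read-out lower numbers stand for stronger inhibition and higher numbers for weaker inhibition:
compound 1, `O=C(N/N=C/c1cc(I)c(O)c(I)c1)c1ccc(I)cc1`; compound 2, `O=C(N/N=C/c1cc(I)c(O)c(I)c1)c1ccc(C(F)(F)F)cc1`; compound 3, `O=C(NNC(=O)c1cc(I)cc(I)c1O)c1ccc(I)cc1`.

In this assay compound 1 reaches only a limit, > 50000 nM. In this assay compound 2 gives 57400 nM, while compound 3 gives 25100 nM. Compound 3 stands lowest of the two numbers, with compound 2 the nearest and the gap between them beyond the scatter. The difference between the cores of compound 1 and compound 3 is not broken down here.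

From compound 1 to compound 2 the change is trifluoromethyl in place of iodo on an aromatic carbon. The step that the limit leaves unreadable from compound 1 to compound 2 cannot be read in size because of the limit of > 50000 nM in this assay, at which 1 of the 3 values shown sits.

Compound 4, `O=C(NNC(=O)c1cc(I)cc(I)c1O)c1ccc(C(F)(F)F)cc1`, carries the same change on the core of compound 3: trifluoromethyl in place of iodo on an aromatic carbon. The step expected from compound 3 to compound 4 is a 1.2-fold higher number from compound 3 to compound 4 (0.08 log units; within the scatter), resting on that single earlier pairing, which gave no readable size. For compound 4 the estimate in this assay is 30000 nM, expected between 12000 nM and 80000 nM.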

Compound 4, half-maximal inhibitory concentration: 167000 nM
For compound 4 the middle estimate is 5.6-fold (0.75 log units) below the measured one; measured number outside the range, above it.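

In this assay, trifluoromethyl in place of iodo on the core of compound 3 gives a 6.7-fold higher number from compound 3 to compound 4 (0.82 log units; beyond the scatter), so the change has a readable size on this core. This single pairing sets no rule for the series. Compound 1 stands at a limit, so the step to compound 2 cannot be read and the size of the change cannot be compared between the two cores: the limit of > 50000 nM in this assay, at which 1 of the 4 values shown sits.

The compounds shown compare only iodo and trifluoromethyl at this place. From the compounds shown here alone, how an amine or a carboxylic acid on the same aromatic carbon would read on either core remains open.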